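Swapping a sulfonate group for bromo on the side chain

A few compounds are considered here, and "the series" means these few. Any claim that something is new, unique, unknown or untested is made for them only; others in the source may bear on it.

Measured in a functional assay on L1210 cells (Mus musculus) for inhibition; a higher number here means a weaker inhibitor, a lower number a stronger inhibitor:
- compound 1 `O=c1[nH]c(=O)n(C2O[C@H](CCl)[C@@H](O)[C@H]2O)cc1F` gives 3400 nM
- compound 2 `Cc1ccc(S(=O)(=O)OC[C@H]2OC(n3cc(F)c(=O)[nH]c3=O)[C@H](O)[C@@H]2O)cc1` gives 460 nM
- compound 3 `CS(=O)(=O)OC[C@H]1OC(n2cc(F)c(=O)[nH]c2=O)[C@H](O)[C@@H]1O` gives 320 nM

Compound 3 and compound 2 cannot be told apart, as a 1.4-fold lower number from compound 2 to compound 3 (0.16 log units; within the scatter) shows. Compound 1 stands clearly apart from them, with an 11-fold lower number from compound 1 to compound 3 (1.03 log units; beyond the scatter).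

The next compound to be measured is compound 4 `O=c1[nH]c(=O)n(C2O[C@H](CBr)[C@@H](O)[C@H]2O)cc1F`. It carries bromo in place of (methylsulfonyl)oxy on a saturated chain carbon bound to a saturated ring carbon, so the difference from compound 3 is bromo in place of (methylsulfonyl)oxy on a saturated chain carbon bound to a saturated ring carbon.

Two measured steps can guide an expectation. The closer one is an 11-fold lower number from compound 1 to compound 3 (1.03 log units; beyond the scatter), where (methylsulfonyl)oxy takes the place of chloro at the same carbon. Compound 4 makes the reverse kind of change, with a single halogen atom replacing that group, so a move back towards the number of compound 1 seems likely. The other step, a 1.4-fold lower number from compound 2 to compound 3 (0.16 log units; within the scatter), changes only the group on the sulfonyl sulfur and says little about a halogen. Within the data shown here, no bromo compound has been measured yet, so the chloro comparison is only a guide.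

In this assay the expected change is a 7.8-fold higher number from compound 3 to compound 4 (0.89 log units; beyond the scatter), a move to a higher number.

Compound 4 is therefore estimated at about 2500 nM, with an expected range of 900 nM to 7000 nM.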

Compound 4, half-maximal inhibitory concentration: 800 nM
Compound 4: the middle estimate sits 3.1-fold (0.49 log units) above what was measured, and the stated range ends above it.
By their numbers in this assay, from the lowest: compounds 3, 2 and 4 (each within the scatter of the next, the first and the last beyond it); then compound 1.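

In this assay, the two halogens at this chain carbon do not behave alike: a 4.3-fold lower number from compound 1 to compound 4 (0.63 log units; beyond the scatter), so the earlier gap between compound 1 and the sulfonates cannot be read as a simple split between halogens and sulfonate groups. A single bromine atom covers more than half of the distance from chloro to (methylsulfonyl)oxy, yet it does not fully match that larger group, since there is a 2.5-fold higher number from compound 3 to compound 4 (0.40 log units; beyond the scatter). At this position, compounds 3, 4 and 1 therefore form an order from (methylsulfonyl)oxy through bromo to chloro, with each of these steps lying beyond the scatter, and nothing shown here accounts for that order.

The compounds shown leave open whether iodo or fluoro at this carbon would extend the order seen with chloro and bromo. They also leave open where an amine, an acetate ester or a longer chain carrying bromo would fall on the same scale.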